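A Halogen Rearrangement from Compound 2 to Compound 3

The compounds below may be only part of what the source reports. "The series", "measured", "known", "first", "only" and "open" are said of these compounds alone.

Measured in an assay on HEK293 cells for inhibition of Toll-like receptor 8 (Homo sapiens), with a stated time of 16 h; a higher number here means a weaker inhibitor, a lower number a stronger inhibitor:
compound 1 `O=C(Nc1ccc(Oc2cc(C(F)(F)F)cc(C(F)(F)F)c2)cc1)c1ccccc1F` — 3000 nM
compound 2 `O=C(Nc1ccc(Oc2cc(C(F)(F)F)cc(C(F)(F)F)c2)cc1)c1c(F)cccc1Br` — 6000 nM

Compound 2 holds the highest of these two numbers. Its nearest neighbour is compound 1, and the step of a 2.0-fold higher number from compound 1 to compound 2 (0.30 log units; within the scatter), bromo in place of hydrogen on an aromatic carbon, lies within the scatter. Compound 3 `O=C(Nc1ccc(Oc2cc(C(F)(F)F)cc(C(F)(F)F)c2)cc1)c1ccc(I)cc1F` differs from compound 2 by 2-fluoro-4-iodophenyl in place of 2-bromo-6-fluorophenyl on a carbonyl carbon. Within the data shown here, no measured step covers this exchange directly. Among the measured compounds shown here, the only step available, a 2.0-fold higher number from compound 1 to compound 2 (0.30 log units; within the scatter), shows that introducing a halogen on that ring changed the number by no more than the scatter, which gives no ground to expect a move in either direction here. The step of a 1.3-fold lower number from compound 2 to compound 3 (0.12 log units; within the scatter) is therefore expected to stay within the scatter. Compound 3 is estimated at 4500 nM, with a range from 1500 nM to 13000 nM.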

Compound 3, half-maximal inhibitory concentration: > 50000 nM
Compound 3: only a limit was reported; the forecaster's own chance of this, stated with the estimate: 10%; at least 11-fold (1.04 log units) between middle value and limit.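

In this assay, compound 3 is reported only as a limit, not as a number: the limit of > 50000 nM in this assay, at which 1 of the 3 values shown sits.

Putting 2-fluoro-4-iodophenyl in place of 2-bromo-6-fluorophenyl on a carbonyl carbon gives an at least 8.3-fold higher number from compound 2 to compound 3 (0.92 log units; beyond the scatter), and the addition of iodo alone gives an at least 16-fold higher number from compound 1 to compound 3 (1.22 log units; beyond the scatter). The earlier step, a 2.0-fold higher number from compound 1 to compound 2 (0.30 log units; within the scatter), stayed within the scatter, so the new result shows that a further halogen on this ring does not always leave the number where it was: this ring can also carry a change that weakens inhibition well beyond the scatter.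

The exchange alters both the halogen and its place on the ring at once, so the compounds shown cannot separate the two. As far as these compounds go, how a chloro, methyl or amine group would behave in the place iodo holds in 2-fluoro-4-iodophenyl remains open.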